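Aryl sulfonyl piperidine series: antiproliferative notes, compound 4

The source may hold more compounds than are shown below. What is called first, only, known or untested is meant among the compounds shown, and "the series" means these compounds.

Measured so far:
compound 1 `CC1CCN(C2CCN(S(=O)(=O)c3cccc(-c4ccccc4F)c3)CC2)CC1` — 10 nM
compound 2 `CC1CCN(C2CCN(S(=O)(=O)c3ccc(Cl)c(C(F)(F)F)c3)CC2)CC1` — 17 nM
compound 3 `Cc1cc(C)c(S(=O)(=O)NC2CCC(N3CCC(C)CC3)CC2)c(C)c1` — 380 nM

In a functional assay on DLD-1 cells (Homo sapiens) for antiproliferative activity, read by CellTiter-Glo, with a stated time of 72 h (on this read-out higher numbers stand for weaker inhibition and lower numbers for stronger inhibition), compound 1 gives the lowest of the three numbers. Compound 2 sits close, within the scatter, so no order between compound 1 and compound 2 can be read from these two values. Compound 3 is far weaker in this assay, and that gap lies well beyond the scatter.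

Compound 4 `Cc1cc(C)cc(-c2cccc(S(=O)(=O)N3CCC(N4CCC(C)CC4)CC3)c2)c1` is the next point. Relative to compound 1 the change is 3,5-dimethylphenyl in place of 2-fluorophenyl on an aromatic carbon. The sulfonyl piperidine core of compound 1 and its attachments are otherwise kept. No measured pair in the set isolates this kind of change, so there is no shown step to lean on; the only guidance is that compound 1 and compound 2, which differ only in the aryl attached to the sulfonyl, both give strong inhibition in this assay.

On that basis the step from compound 1 to compound 4 is expected to be small, at most a slight loss, and is estimated as a 1.5-fold higher number from compound 1 to compound 4 (0.18 log units; within the scatter). For compound 4 in this assay the estimate is 15 nM, with a range of 5 nM to 60 nM.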

Compound 4, half-maximal inhibitory concentration: 41 nM
Compound 4: the middle estimate sits 2.7-fold (0.44 log units) below what was measured; the measured number falls inside the stated range.
By their numbers in this assay, from the lowest: compounds 1 and 2 (each within the scatter of the next); then compound 4; then compound 3.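

Among these compounds, this is the first single-place step: in this assay, 3,5-dimethylphenyl in place of 2-fluorophenyl, on an aromatic carbon meta to a large group, gives a 4.1-fold higher number from compound 1 to compound 4 (0.61 log units; beyond the scatter), a modest loss that lies beyond the scatter. The number therefore responds to which aryl sits at this position, although the swap is not ruinous, as compound 4 stays at 41 nM with the rest of compound 1 kept. No measurement shown here accounts for the loss, so the step records a size and gives no reason.

The step removes the fluorine and adds two methyl groups at once, so the compounds shown cannot separate these two parts of the change; an unsubstituted phenyl or a single methyl on the same ring would begin to do so. Among the compounds shown here, also open is how this position responds to an aryl bearing an amine or a carboxylic acid, or to a pyridine ring in place of the carbon-only aromatic ring, since every aryl at this position so far carries neither.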